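Thiophene for furan on the saturated ring carbon of compound 3

The source may report more compounds than this note shows. Statements on the series, on what has been measured and on what is new or still open speak of the compounds shown alone.

Measured in a functional assay on PC-3 cells (Homo sapiens) for cytotoxicity, read by MTT assay, with a stated time of 48 h; a lower number here means a stronger inhibitor, a higher number a weaker inhibitor:
compound 1 `COc1cc(-c2nnc3n2NC(c2cccs2)C(C(=O)c2ccc(C)cc2)S3)cc(OC)c1OC` — 5090 nM
compound 2 `COc1cc(-c2nnc3n2NC(c2cccs2)C(C(=O)c2ccc(F)cc2)S3)cc(OC)c1OC` — 27400 nM
compound 3 `COc1ccc(C(=O)C2Sc3nnc(-c4cc(OC)c(OC)c(OC)c4)n3NC2c2ccco2)cc1` — > 100000 nM

Compound 3 returns only a limit in this assay, not a number; it sits at the limit of > 100000 nM in this assay, at which 1 of the 3 values shown sits. Compound 4 `COc1ccc(C(=O)C2Sc3nnc(-c4cc(OC)c(OC)c(OC)c4)n3NC2c2cccs2)cc1` differs from it by thiophen-2-yl in place of furan-2-yl on a saturated ring carbon. No measured step touches this position: the one step shown, a 5.4-fold higher number from compound 1 to compound 2 (0.73 log units; beyond the scatter), concerns the substituent on the aryl ketone instead, and both compounds 1 and 2 already carry the thiophen-2-yl group while reaching numbers below the limit. The change from compound 3 to compound 4 therefore is expected to move the value downward into measurable range, but with wide uncertainty, an expected step of an at least 2.5-fold lower number from compound 3 to compound 4 (0.39 log units; beyond the scatter). For compound 4 the expected value in this assay is 40000 nM, between 8000 nM and 100000 nM.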

Compound 4, half-maximal inhibitory concentration: 95900 nM
Compound 4: middle estimate off by 2.4-fold (0.38 log units), on the low side, within the range that was stated.
By their numbers in this assay, from the lowest: compound 1; then compound 2; then compound 4. At a limit, above all of these: compound 3.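

In this assay, thiophen-2-yl in place of furan-2-yl on the saturated ring carbon gives an at least 1.0-fold lower number from compound 3 to compound 4 (0.01 log units; that floor lies within the scatter), so this change shows no gain beyond the scatter. Compound 3 is held at a limit of the assay, not a number: the limit of > 100000 nM in this assay, at which 1 of the 4 values shown sits. With thiophen-2-yl kept, the aryl ketone substituent sets the number: methoxy gives a 3.5-fold higher number from compound 2 to compound 4 (0.54 log units; beyond the scatter) and a 19-fold higher number from compound 1 to compound 4 (1.28 log units; beyond the scatter).

Open, as far as these compounds go, is how furan-2-yl reads with methyl or fluoro on the aryl ketone. Also open, from the compounds shown here alone, is how a phenyl group on the saturated ring carbon, or an amine on the aryl ketone, would read.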